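The source may hold more compounds than are shown below. What is called first, only, known or untested is meant among the compounds shown, and "the series" means these compounds.

Compound 1 `Cc1c(C2CC2)nc2cnc(-n3ccc(OCc4ccc(Cl)cc4)cc3=O)cn12` — 44 nM
Compound 2 `Cn1c(C2CC2)nc2ccc(-n3ccc(OCc4ccc(Cl)cc4)cc3=O)cc21` — 35 nM
Compound 3 `CCn1c(C2CC2)nc2ccc(-n3ccc(OCc4ccc(Cl)cc4)cc3=O)cc21` — 37 nM

In an assay on CHO cells for displacement of a labelled ligand from melanin-concentrating hormone receptor 1 (Homo sapiens), read by scintillation counting, with a stated time of 1 h (a higher number here means a weaker inhibitor, a lower number a stronger inhibitor), compound 2 gives 35 nM, the lowest of the three numbers, though its neighbours sit close: compound 3 gives 37 nM and compound 1 gives 44 nM, both within the scatter of compound 2, so no order among the three can be claimed.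

Compound 4 `Cn1c(C2CC2)nc2ccc(-n3ccc(OCc4ncc(Cl)cn4)cc3=O)cc21` is the unmeasured analogue. It differs from compound 2 in one place: 5-chloropyrimidin-2-yl in place of 4-chlorophenyl on a saturated chain carbon bound to an oxygen on an aromatic ring.

For the measured compounds named here, none of the measured steps bears on this change. Going by the values given here, the only step available, a 1.1-fold higher number from compound 2 to compound 3 (0.02 log units; within the scatter), concerns a methyl on the chain carbon bound to the aromatic nitrogen, far from the ether side chain, and it was flat. The pair compound 1 and compound 2 alters the core, not the chloroaryl group, and their values also sit within the scatter. Among the compounds with values here, the exchange of a carbon-only ring for one with two hetero atoms at this position therefore has no precedent here, and the estimate for compound 4 rests on the step being undetermined rather than supported.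

Compound 4 is expected to give about 70 nM in this assay, a range of 25 nM to 220 nM, which means an expected step of a 2.0-fold higher number from compound 2 to compound 4 (0.30 log units; within the scatter), with a slightly weaker number held as the more likely outcome.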

Compound 4, half-maximal inhibitory concentration: > 1000 nM
Compound 4 gave a limit, no number; the forecaster's own chance of this, stated with the estimate: 3%; middle value at least 14-fold (1.15 log units) from the limit.
By their numbers in this assay, from the lowest: compounds 2, 3 and 1 (each within the scatter of the next). At a limit, above all of these: compound 4.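

In this assay, for the compounds shown here, the earlier compounds differed only away from the ether side chain and stayed within the scatter of one another, so they gave no sign of how this position would respond. It now proves highly sensitive to the ring carried on the saturated chain carbon bound to an oxygen on an aromatic ring: 5-chloropyrimidin-2-yl in place of 4-chlorophenyl, with the same number of heavy atoms and no net charge on either group, gives an at least 28-fold higher number from compound 2 to compound 4 (1.45 log units; beyond the scatter), the only step shown that lies beyond the scatter. The reading for compound 4 is a limit of the assay, not a number: the limit of > 1000 nM in this assay, at which 1 of the 4 values shown sits.

The compounds shown leave open whether the loss needs both ring nitrogens or follows from one alone, a question that a 5-chloropyridin-2-yl in the same place would separate. Also open, from the compounds shown here alone, is whether a 4-fluorophenyl, or 2-(4-chlorophenyl)ethyl in place of 4-chlorobenzyl, would stay close to compound 2 at 35 nM, and whether the same exchange would act alike on the core of compound 1.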